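The source may hold more compounds than are shown below. What is called first, only, known or untested is meant among the compounds shown, and "the series" means these compounds.

Of the compounds shown here, two have been measured so far in a functional assay on the whole organism for inhibition, with Cavia porcellus as the target, at a dose of 10 mg/kg by the oral route; on this read-out lower numbers stand for a weaker effect and higher numbers for a stronger effect at the one dose given. Compound 1, with the structure `COc1ccc(-c2nc(C(C)C)sc2-c2ccc(OC)cc2)cc1`, gives 100%. Among the compounds with values here, compound 2, with the structure `COc1ccc(-c2nc(CC(N)=O)sc2-c2ccc(OC)cc2)cc1`, gives 100% in this assay, so compound 2 stands level with compound 1 at the digits reported, and the single measured step, no change at the digits printed from compound 1 to compound 2 (within the scatter), lies within the scatter. Compound 3 has the structure `COc1ccc(-c2nc(C(F)(F)F)sc2-c2ccc(OC)cc2)cc1` and has not yet been measured. It differs from compound 2 in one place: trifluoromethyl in place of carbamoylmethyl on an aromatic carbon. Within the data shown here, the only measured step put carbamoylmethyl in place of isopropyl on an aromatic carbon and left the read-out unchanged; no measured step involves trifluoromethyl, so there is no direct guide to how large this change will be. Because compound 2 gives 100% and compound 1 gives 100%, the expectation is that compound 3 stays near that level, and the step of a number 10 percentage points lower from compound 2 to compound 3 (within the scatter) is expected to be small. Compound 3 is therefore estimated to give 90%, with a range from 60% to 100%.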

Compound 3, a percentage reported as inhibition, in the whole organism at one dose (the size of the read-out at that dose, not a potency): 100%
For compound 3 the middle estimate is 10 percentage points below the measured one; the measured number falls inside the stated range.
By their numbers in this assay, from the lowest: compounds 1, 2 and 3 (each within the scatter of the next).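

In this assay the swap of carbamoylmethyl for trifluoromethyl gives no change at the digits printed from compound 2 to compound 3 (within the scatter), and the comparison with isopropyl gives no change at the digits printed from compound 1 to compound 3 (within the scatter). This shows that, on this aromatic carbon of the five-membered ring with 1 nitrogen and 1 sulfur, carbamoylmethyl, with its 1 hydrogen-bond donor and 1 hydrogen-bond acceptor, is not required for the full read-out at this dose: trifluoromethyl, with 0 hydrogen-bond donors and 0 hydrogen-bond acceptors, does just as well, and three different groups now sit level here. No supporting measurement is available to explain this result.

On these data alone, all three compounds give the same number at the one dose, so the read-out does not separate them, and whether they would differ at a lower dose remains open. It is also open whether this position tolerates every kind of group, since the compounds shown say nothing about a carboxylic acid, an amine, a longer alkyl chain or a plain hydrogen there, nor about what happens when either 4-methoxyphenyl group is changed.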